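A few compounds are considered here, and "the series" means these few. Any claim that something is new, unique, unknown or untested is made for them only; others in the source may bear on it.

Compound 1 `COc1ccc(-n2cc(CNCCN3CCN(C)CC3)c(-c3ccccc3C)n2)cc1` gives > 20000 nM in an ADME assay on Huh-7 cells (Homo sapiens) for cytotoxicity (on this read-out higher numbers stand for lower toxicity in this test and lower numbers for higher toxicity in this test), which is a limit of the assay. Compound 2 `CN1CCN(CCNCc2cn(-c3ccc(C(F)(F)F)cc3)nc2-c2ccc(OC(F)(F)F)cc2)CC1` gives 3000 nM. Compound 3 `Cc1ccccc1-c1nn(-c2ccc(F)c(F)c2)cc1CNCCN1CCN(C)CC1` gives > 20000 nM, again a limit.

Compound 3 therefore stands at the limit of > 20000 nM in this assay, at which 2 of the 3 values shown sit. Going by the values given here, its only measured step cannot be sized, because a step that the two limits leave unreadable from compound 1 to compound 3 joins two limits. The change now considered is 4-(trifluoromethyl)phenyl in place of 3,4-difluorophenyl on an aromatic nitrogen, giving compound 4 `Cc1ccccc1-c1nn(-c2ccc(C(F)(F)F)cc2)cc1CNCCN1CCN(C)CC1`. Among the compounds with values here, no measured step covers this change. Compound 2 carries the same 4-(trifluoromethyl)phenyl on the aromatic nitrogen, yet differs from compound 4 in the other aryl group too, so its value is only a weak pointer. Compound 4 is expected at 10000 nM, between 3000 nM and 20000 nM, which would mean an expected step of an at least 2.0-fold lower number from compound 3 to compound 4 (0.30 log units; that floor lies within the scatter).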

Compound 4, half-maximal cytotoxic concentration: 11000 nM
Compound 4: middle estimate off by 1.1-fold (0.04 log units), on the low side; the measured number falls inside the stated range.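

In this assay the 4-(trifluoromethyl)phenyl group on the aromatic nitrogen, with 2-methylphenyl kept in place, gives an at least 1.8-fold lower number from compound 3 to compound 4 (0.25 log units; that floor lies within the scatter) and, measured against the methoxy group of the other compound, an at least 1.8-fold lower number from compound 1 to compound 4 (0.25 log units; that floor lies within the scatter). Both are floors only, so this position is not yet shown to act beyond the scatter. With the nitrogen group held fixed, the aryl group on the aromatic carbon does count, at a 3.7-fold higher number from compound 2 to compound 4 (0.56 log units; beyond the scatter).

Going by these compounds, how a nitrile or an amine on that phenyl ring would read remains open. On these data alone, the true size of both floors also stays open, with compound 1 and compound 3 resting on limits: the limit of > 20000 nM in this assay, at which 2 of the 4 values shown sit.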